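The compounds below may be only part of what the source reports. "The series", "measured", "known", "first", "only" and "open" are said of these compounds alone.

Compound 1 `Cc1ccc2nc(/N=C3\C(=O)N(CN(c4ccccc4)c4ccccc4)c4ccccc43)sc2c1`: 39200 nM
Compound 2 `CN(C)CN1C(=O)C(=O)c2c(Br)cccc21`: 57600 nM
Compound 3 `Cc1ccc2nc(/N=C3\C(=O)N(CN4CCCCC4)c4cccc(Br)c43)sc2c1`: 39100 nM

All three numbers come from a functional assay on MCF7 cells (Homo sapiens) for cytotoxicity, read by sulforhodamine B assay, with a stated time of 48 h; a higher number here means a weaker inhibitor of growth, a lower number a stronger inhibitor of growth. Compound 2 is separated from each of the other two by a gap that lies within the usual scatter of repeated runs, so the three compounds cannot be told apart on these numbers. Compound 4 `CN(C)CN1C(=O)C(=O)c2c(Cl)cccc21` has not yet been measured. It differs from compound 2 in a single place: chloro in place of bromo on an aromatic carbon. Within the data shown here, no pair of measured compounds that differ in one place is available to show what such a swap does in this assay. With nothing to suggest otherwise, the step of a 1.0-fold higher number from compound 2 to compound 4 (0.00 log units; within the scatter) is expected to stay within the scatter, in no particular direction. Compound 4 is therefore estimated at 58000 nM, with a range from 29000 nM to 116000 nM.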

Compound 4, concentration for 50% growth inhibition: 87800 nM
Beside the measured number, compound 4's estimate is 1.5-fold (0.18 log units) below it; measured number inside the range.
By their numbers in this assay, from the lowest: compounds 3, 1, 2 and 4 (each within the scatter of the next, the first and the last beyond it).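

Among these compounds, this is the first one-place swap that can be read in this assay: chloro in place of bromo on an aromatic carbon gives a 1.5-fold higher number from compound 2 to compound 4 (0.18 log units; within the scatter), so the two halogens cannot be told apart at this position. No supporting measurement bears on this result.

As far as these compounds go, whether a methoxy group or a carboxylic acid on the same carbon would move the number beyond the scatter remains open. So does whether this swap would read the same in compound 3, which also carries bromo.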